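A single ring swap from compound 2 to compound 3

The source may hold more compounds than are shown below. What is called first, only, known or untested is meant among the compounds shown, and "the series" means these compounds.

Measured in a functional assay on A549 cells (Homo sapiens) for inhibition, read by MTT assay, with a stated time of 48 h; on this read-out lower numbers stand for stronger inhibition and higher numbers for weaker inhibition:
Compound 1 `O=C(Nc1ccccn1)Nc1cc(-c2cncnc2)ccc1OC(F)(F)F`: 15200 nM
Compound 2 `COc1ccc(-c2ccc(OC(F)(F)F)c(NC(=O)Nc3ccncc3)c2)cn1`: > 300000 nM (a limit)

Compound 2 stands only at a limit: its > 300000 nM is a limit of this assay and not a number. Compound 3 `O=C(Nc1ccncc1)Nc1cc(-c2cncnc2)ccc1OC(F)(F)F` carries pyrimidin-5-yl in place of 6-methoxypyridin-3-yl on an aromatic carbon. Going by the values given here, no measured step shows this change. Compound 1 also carries pyrimidin-5-yl and gives 15200 nM, so stronger inhibition is expected, though its size is uncertain. The expected change runs an at least 6.0-fold lower number from compound 2 to compound 3 (0.77 log units; beyond the scatter). For compound 3 the estimated value is 50000 nM, with an expected range of 12000 nM to 250000 nM.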

Compound 3, half-maximal inhibitory concentration: 3750 nM
The estimate for compound 3 lay 13-fold (1.12 log units) above the measured number; the measured number lies below the stated range.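

In this assay, pyrimidin-5-yl in place of 6-methoxypyridin-3-yl on an aromatic carbon gives an at least 80-fold lower number from compound 2 to compound 3 (1.90 log units; beyond the scatter), so this position, para to a trifluoromethoxy group, can carry a large share of the read-out. Compound 2 stands at a limit and not at a number: the limit of > 300000 nM in this assay, at which 1 of the 3 values shown sits. With pyrimidin-5-yl held, pyridin-4-yl in place of pyridin-2-yl on an amide-type nitrogen gives a 4.1-fold lower number from compound 1 to compound 3 (0.61 log units; beyond the scatter), so this second place also moves the read-out.

The compounds shown do not separate the change of ring from the loss of the methoxy group. Going by these compounds, what a pyridin-3-yl group, or an amine on the pyrimidin-5-yl ring, would give here remains open.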